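Replacing a bromo-hydroxyphenyl ring with a chlorophenyl ring

The compounds below may be only part of what the source reports. "The series", "measured", "known", "first", "only" and "open" are said of these compounds alone.

Measured compounds:
compound 1 `O=C(/C(=C\c1ccc(Br)c(O)c1)Sc1ccc(Br)cc1)c1ccc(Br)cc1` gives 1000 nM
compound 2 `CCOc1ccc(/C=C(/SCc2ccc(Cl)c(Cl)c2)C(=O)c2ccc(Cl)cc2)cc1OC` gives 25000 nM
compound 3 `O=C(/C(=C\c1ccc(Br)c([N+](=O)[O-])c1)Sc1ccc(Br)cc1)c1ccc(Br)cc1` gives 1000 nM

All three were tested in a functional assay on DU-145 cells (Homo sapiens) for inhibition, read by trypan blue exclusion, with a stated time of 96 h; a higher number here means a weaker inhibitor of growth, a lower number a stronger inhibitor of growth. Compound 1 stands level with compound 3 within the scatter, and these two share the lowest numbers of the set. The step of no change at the digits printed from compound 1 to compound 3 (within the scatter) shows that exchanging hydroxy for nitro on that ring left the number where it was. Within the data shown here, compound 2, built differently at several points, gives a number that is far higher; no single-change step links it to compound 1, so only the two values themselves can be compared.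

The unmeasured compound 4 `O=C(/C(=C\c1ccc(Cl)cc1)Sc1ccc(Br)cc1)c1ccc(Br)cc1` differs from compound 1 as follows: 4-chlorophenyl in place of 4-bromo-3-hydroxyphenyl on a double-bonded chain carbon bound to a double-bonded chain carbon. Among the measured compounds shown here, no measured step makes exactly this change. For the measured compounds named here, the only step that touches the same ring, no change at the digits printed from compound 1 to compound 3 (within the scatter), was within the scatter, which hints that substituents on this ring can be changed without much effect, though a nitro-for-hydroxy swap is not the same as removing the hydroxy and changing the halogen. Compound 4 is therefore expected to stay close to compound 1, with the step of a 1.5-fold higher number from compound 1 to compound 4 (0.18 log units; within the scatter) estimated as small. The estimated value for compound 4 is 1500 nM, with a range from 500 nM to 5000 nM.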

Compound 4, concentration for 50% growth inhibition: 1000 nM
For compound 4 the middle estimate is 1.5-fold (0.18 log units) above the measured one; low and high end bracket the measured number.
By their numbers in this assay, from the lowest: compounds 1, 3 and 4 (each within the scatter of the next); then compound 2.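

In this assay, placing 4-chlorophenyl where 4-bromo-3-hydroxyphenyl stood, on a double-bonded chain carbon bound to a double-bonded chain carbon, gives no change at the digits printed from compound 1 to compound 4 (within the scatter). The earlier swap put a nitro where the hydroxy had been, whereas this change takes the hydroxy away with nothing in its place and exchanges bromine for chlorine, so among these compounds the number does not rest on that hydroxy or on that bromine. Nothing measured here explains why the number holds through this change.

Going by these compounds, because the hydroxy and the bromine leave in a single step, the effect of each alone stays unknown. Also open, on these data alone, is whether a ring carrying an amine or a carboxylic acid, or an unsubstituted phenyl ring, would hold the number at this position.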